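Ether chain variation on the shared core

The source may hold more compounds than are shown below. What is called first, only, known or untested is meant among the compounds shown, and "the series" means these compounds.

Among the compounds with values here, two ethers on the shared core carry numbers so far. Compound 1 `Nc1ccc2cccc(OCC3CCCC3)c2n1` gives 53 nM in an assay on cells with melanin-concentrating hormone receptor 1 (Homo sapiens) as the target, read by radioligand binding; on this read-out higher numbers stand for weaker inhibition and lower numbers for stronger inhibition. Compound 2 `CCCCCOc1cccc2ccc(N)nc12` gives 580 nM in this assay. Within the data shown here, the single step in hand, an 11-fold higher number from compound 1 to compound 2 (1.04 log units; beyond the scatter), places compound 2 at the highest of the two numbers, with compound 1 its only neighbour, and that step lies beyond the scatter.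

Compound 3 `COC(C)(C)CCOc1cccc2ccc(N)nc12` is not yet measured. Relative to compound 2 it carries 1-methoxy-1-methylethyl in place of propyl on a saturated chain carbon, two bonds along the chain from an oxygen on an aromatic ring. Among the measured compounds shown here, no measured pair shows this change. For the measured compounds named here, the one step available, an 11-fold higher number from compound 1 to compound 2 (1.04 log units; beyond the scatter), concerns the other end of the chain, where a cyclopentyl gave the lower number and a straight butyl the higher one; it bears on compound 3 only loosely, in that a branched terminus reappears, while the added acceptor has no precedent. The expected step of a 1.7-fold lower number from compound 2 to compound 3 (0.22 log units; within the scatter) is therefore small and may stay within the scatter. Compound 3 is estimated at 350 nM, with a range from 90 nM to 1400 nM in this assay.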

Compound 3, half-maximal inhibitory concentration: 132 nM
Compound 3: the middle estimate sits 2.7-fold (0.42 log units) above what was measured; the measured number falls inside the stated range.
By their numbers in this assay, from the lowest: compound 1; then compound 3; then compound 2.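

In this assay, the position on a saturated chain carbon, two bonds along the chain from an oxygen on an aromatic ring, responds to substitution: 1-methoxy-1-methylethyl in place of propyl gives a 4.4-fold lower number from compound 2 to compound 3 (0.64 log units; beyond the scatter), so an open chain need not carry a number as high as that of compound 2. Set against the cyclopentyl ether, 2-methoxy-2-methylpropyl in place of cyclopentyl still leaves a 2.5-fold higher number from compound 1 to compound 3 (0.40 log units; beyond the scatter), so the gap to compound 1 narrows without closing, and compound 1 keeps the lowest number of the three. No data in hand bear on the cause of either step.

The change brings in branching and a methoxy group together, and the compounds shown do not tell which of the two goes with the lower number. A 3,3-dimethylbutyl ether would address the branching without the oxygen, while a terminal hydroxyl or an amine at the same chain carbon would show whether the methoxy group can be exchanged.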